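Imidazoline-fused bicyclic series: aryl swap at the aromatic ring

The source may report more compounds than this note shows. Statements on the series, on what has been measured and on what is new or still open speak of the compounds shown alone.

Measured compounds
- compound 1 `COc1c(C)ccc2c1CCC2c1ncc[nH]1`: > 10000 nM (a limit of the assay)
- compound 2 `c1cc(-c2ccn[nH]2)c2c(c1)C(c1ncc[nH]1)CC2`: 336 nM
- compound 3 `CS(=O)(=O)Nc1c(Cl)ccc2c1CCCC2c1ncc[nH]1`: > 10000 nM (a limit of the assay)

In a functional assay on CHO cells for agonist activity at Alpha-1D adrenergic receptor (Homo sapiens), read by FLIPR and calcium flux (on this read-out higher numbers stand for an effect only at larger amounts of compound and lower numbers for an effect already at smaller amounts), compound 2 gives 336 nM, the only numerical result among the three measured compounds. For compound 1 the outcome in this assay is a limit of the assay, > 10000 nM. For compound 3 the outcome is likewise a limit of the assay, > 10000 nM. Thus compound 2 stands apart from the other two, which both sit at the limit of > 10000 nM in this assay, at which 2 of the 3 values shown sit. Among the measured compounds shown here, compound 1 and compound 3 differ from compound 2 in more than one place, so no single step between measured compounds can be read off.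

Compound 4 `c1cncc(-c2cccc3c2CCC3c2ncc[nH]2)c1` is the next compound to be measured in this assay. It differs from compound 2 by one change: pyridin-3-yl in place of 1H-pyrazol-5-yl on an aromatic carbon. The pyrazolyl group of compound 2 carries one hydrogen-bond donor, the pyridin-3-yl group of compound 4 none, as counted in that difference. No measured step in the series tells how this aryl swap plays out, and nothing among the measured results gives a cause for any of them beyond the limits themselves.

The step is therefore expected to be a loss of modest size, a 3.0-fold higher number from compound 2 to compound 4 (0.47 log units; beyond the scatter), with a fair chance that it stays within the scatter. Compound 4 is estimated at 1000 nM, with a range from 200 nM to 6000 nM.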

Compound 4, half-maximal effective concentration: > 10000 nM
Compound 4: no number, only a limit; the forecaster's own chance of this, stated with the estimate: 20%; middle value at least 10-fold (1.00 log units) away from the limit.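

In this assay compound 4 gives > 10000 nM, which is a limit of the assay and not a number. Pyridin-3-yl in place of 1H-pyrazol-5-yl on this aromatic carbon, ortho to a fused ring and meta to a fused ring, gives an at least 29-fold higher number from compound 2 to compound 4 (1.47 log units; beyond the scatter), the only step in the series that can be read so far, and it shows that the result at this position depends strongly on which aromatic ring sits there. The full size of the step stays unknown because compound 4 sits at the limit of the assay, so the step gives only a lower bound: the limit of > 10000 nM in this assay, at which 3 of the 4 values shown sit.

The swap changes ring size, the count of hetero atoms and the count of hydrogen-bond donors together, and the compounds shown do not separate these changes from one another. Going by these compounds, how a phenyl, a 1H-imidazol-4-yl or a primary amide would read on this same carbon stays open, as does whether any group other than 1H-pyrazol-5-yl gives a numerical result here.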